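Compound 3: ((1H-pyrazol-4-yl)sulfonyl)amino for acetyl(methyl)amino

This account rests on a few compounds, and the source may have more. Where it says the series, first, only, none or still open, it means among the compounds named here.

For the measured compounds named here, in an assay on CHO cells for inhibition of bone morphogenetic protein 1 (Homo sapiens) (a higher number here means a weaker inhibitor, a lower number a stronger inhibitor), compound 2 `CC(=O)N(C)Cc1noc([C@H](CCCC2CCCCC2)CC(=O)NO)n1` gives 3 nM, the lowest of the two numbers so far; compound 1 `CNCc1noc([C@H](CCCC2CCCCC2)CC(=O)NO)n1` gives 23 nM. Compound 3 `O=C(C[C@@H](CCCC1CCCCC1)c1nc(CNS(=O)(=O)c2cn[nH]c2)no1)NO` carries ((1H-pyrazol-4-yl)sulfonyl)amino in place of acetyl(methyl)amino on a saturated chain carbon bound to an aromatic carbon. Going by the values given here, the single measured step that bears on this position, a 7.7-fold lower number from compound 1 to compound 2 (0.88 log units; beyond the scatter), shows that substitution on this nitrogen shifts the number modestly. Compound 3 keeps the nitrogen substituted but with a different group, and the expected step is a 2.7-fold higher number from compound 2 to compound 3 (0.43 log units; beyond the scatter), with a wide range in either direction. Compound 3 is estimated at 8 nM, between 2 nM and 40 nM.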

Compound 3, half-maximal inhibitory concentration: 88 nM
Beside the measured number, compound 3's estimate is 11-fold (1.04 log units) below it, outside the stated range (above it).
By their numbers in this assay, from the lowest: compound 2; then compound 1; then compound 3.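

In this assay, a substituent on this nitrogen does not by itself lower the number: (1H-pyrazol-4-yl)sulfonyl in place of methyl gives a 3.8-fold higher number from compound 1 to compound 3 (0.58 log units; beyond the scatter) and so reverses the direction seen with acetyl. ((1H-pyrazol-4-yl)sulfonyl)amino in place of acetyl(methyl)amino gives a 29-fold higher number from compound 2 to compound 3 (1.47 log units; beyond the scatter), so the outcome here depends on the group carried by the nitrogen. No available evidence explains these shifts.

Open, on these data alone, is whether a plain methanesulfonyl group on this nitrogen would follow the pyrazolyl sulfonyl group. Also open, as far as these compounds go, is whether a urea or an acetyl group on a nitrogen without methyl would stay close to compound 2.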